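Propyl in place of tert-butyl on compound 3

The compounds below may be only part of what the source reports. "The series", "measured", "known", "first", "only" and "open" are said of these compounds alone.

Measured in a functional assay (aorta) with Rattus norvegicus as the target; on this read-out lower numbers stand for stronger inhibition and higher numbers for weaker inhibition:
- compound 1 `CC(C)(C)NCCCOc1ccc(S(=O)(=O)c2c(C(C)(C)C)cn3ccccc23)cc1`: 443 nM
- compound 2 `CCCN(CCC)CCCOc1ccc(S(=O)(=O)c2c(C)cn3ccccc23)cc1`: 957 nM
- compound 3 `CCCCN(CCCC)CCCOc1ccc(S(=O)(=O)c2c(C(C)(C)C)cn3ccccc23)cc1`: 51.9 nM

Compound 3 has the lowest number of the three. Compound 4 `CCCCN(CCCC)CCCOc1ccc(S(=O)(=O)c2c(CCC)cn3ccccc23)cc1` puts propyl in place of tert-butyl on an aromatic carbon. Within the data shown here, the one measured step, an 8.5-fold lower number from compound 1 to compound 3 (0.93 log units; beyond the scatter), lies on the saturated chain and not at this carbon, so it gives no direct size for this change. Compound 2 gives a higher number than compound 3, but the two differ in more than one place. No step beyond the scatter is therefore firmly expected in this assay. For compound 4 the estimated value is 60 nM, with an expected range of 15 nM to 250 nM. The expected step reads a 1.2-fold higher number from compound 3 to compound 4 (0.06 log units; within the scatter).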

Compound 4, half-maximal inhibitory concentration: 54.3 nM
The estimate for compound 4 lay 1.1-fold (0.04 log units) above the measured number, and the stated range covers the measured number.
By their numbers in this assay, from the lowest: compounds 3 and 4 (each within the scatter of the next); then compound 1; then compound 2.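

In this assay, among these compounds, propyl in place of tert-butyl on this aromatic carbon gives a 1.0-fold higher number from compound 3 to compound 4 (0.02 log units; within the scatter), the first direct reading at this position. With the dibutylamino chain held constant, tert-butyl is therefore not required here to keep the number at this level. No available evidence explains this match.

Open, on these data alone, is how a phenyl ring, a carboxylic acid or an amine would read at this carbon. Also open, as far as these compounds go, is whether propyl and tert-butyl still match when the chain carries the (tert-butyl)amino group of compound 1.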